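The source may report more compounds than this note shows. Statements on the series, on what has been measured and on what is new or still open speak of the compounds shown alone.

Four compounds share a core in which a chlorinated, cyano-bearing chain carries a carbonyl group attached to an indole. Compound 1, `COc1ccc(/C(Cl)=C/C=C(\C#N)C(=O)c2c(C)[nH]c3ccccc23)cc1`, bears a methyl on the indole and a single methoxy on the outer ring; in an ADME assay on Vero cells (Chlorocebus sabaeus) for cytotoxicity, read by sulforhodamine B assay, with a stated time of 48 h (a higher number here means a weaker inhibitor of growth, a lower number a stronger inhibitor of growth), compound 1 gives "not determined" (no result reported), so no number is in hand for it. Compound 2, `COc1cc(/C(Cl)=C/C=C(\C#N)C(=O)c2c[nH]c3ccc(Br)cc23)cc(OC)c1OC`, carries a bromine on the indole and three methoxy groups on the outer ring. Compound 3, `COc1ccc(/C(Cl)=C/C=C(\C#N)C(=O)c2c[nH]c3ccc(Br)cc23)cc1OC`, keeps the bromine but has two methoxy groups. In this assay compound 2 gives 22100 nM, the lowest of the two numbers available, while compound 3 gives 38400 nM; the step of a 1.7-fold higher number from compound 2 to compound 3 (0.24 log units; within the scatter) is within the scatter.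

Compound 4, `COc1cc(/C(Cl)=C/C=C(\C#N)C(=O)c2c(C)[nH]c3ccccc23)cc(OC)c1OC`, differs from compound 2 by 2-methyl-1H-indol-3-yl in place of 5-bromo-1H-indol-3-yl on a carbonyl carbon. Among the compounds with values here, no measured step touches this part of the molecule; the only step in hand, a 1.7-fold higher number from compound 2 to compound 3 (0.24 log units; within the scatter), concerns a methoxy on the outer ring and was within the scatter. There is therefore no basis to expect a change beyond the scatter, so the step of a 1.1-fold higher number from compound 2 to compound 4 (0.05 log units; within the scatter) is expected to stay small. Compound 4 is estimated to give 25000 nM in this assay, within a range from 8000 nM to 70000 nM.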

Compound 4, concentration for total growth inhibition: 42600 nM
Compound 4: the middle estimate sits 1.7-fold (0.23 log units) below what was measured; the measured number falls inside the stated range.
By their numbers in this assay, from the lowest: compounds 2, 3 and 4 (each within the scatter of the next).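

The group on the carbonyl carbon now has a measured step of its own, whereas the earlier step concerned only a methoxy: in this assay, 2-methyl-1H-indol-3-yl in place of 5-bromo-1H-indol-3-yl gives a 1.9-fold higher number from compound 2 to compound 4 (0.29 log units; within the scatter) and stays within the usual scatter. For this pair, then, a bromine leaves and a methyl enters in one exchange without a change that can be told from repeat-to-repeat variation, although the two edits arrive together and their separate contributions cannot be told apart. Nothing is in hand that explains this result.

Compound 1 gives "not determined" (no result reported) and so leaves the methoxy step among compounds carrying 2-methyl-1H-indol-3-yl unreadable. Open too, from the compounds shown here alone, is whether plain 1H-indol-3-yl, which has neither the bromine nor the methyl, or an indole carrying an amine or a carboxylic acid, would also stay within the scatter on the same carbonyl carbon.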